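This account rests on a few compounds, and the source may have more. Where it says the series, first, only, none or still open, it means among the compounds named here.

Working notes on the series around compound 3 `CC(C)(C)OC(=O)NCCNC(=O)CN1CN(c2ccccc2)C2(CCN(C(=O)c3ccc(C4CCCCC4)cc3)CC2)C1=O`. In an assay on HEK293 cells for displacement of a labelled ligand from NPC1-like intracellular cholesterol transporter 1 (Homo sapiens) (a lower number here means a stronger inhibitor, a higher number a weaker inhibitor), compound 3 gives 5500 nM, the highest of the three numbers recorded so far. Compound 1 `CC(C)(C)OC(=O)NCNC(=O)CN1CN(c2ccccc2)C2(CCN(C(=O)c3ccc(C4CCCCC4)cc3)CC2)C1=O` gives 1700 nM, and compound 2 `O=C(CN1CN(c2ccccc2)C2(CCN(C(=O)c3ccc(C4CCCCC4)cc3)CC2)C1=O)N1CCCCC1` gives 1100 nM. Both steps that lead into compound 3 raise the number: a 3.2-fold higher number from compound 1 to compound 3 (0.51 log units; beyond the scatter) and a 5.0-fold higher number from compound 2 to compound 3 (0.70 log units; beyond the scatter). Between the two lower-numbered compounds the step is a 1.5-fold lower number from compound 1 to compound 2 (0.19 log units; within the scatter).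

Compound 4 `CC1(C)CC(OC(=O)CN2CN(c3ccccc3)C3(CCN(C(=O)c4ccc(C5CCCCC5)cc4)CC3)C2=O)CC(C)(C)N1` differs from compound 3 in one place on the carbonyl carbon attached to a saturated chain carbon: (2,2,6,6-tetramethylpiperidin-4-yl)oxy in place of (2-((tert-butoxycarbonyl)amino)ethyl)amino on a carbonyl carbon. The group that leaves is the one whose arrival in place of piperidin-1-yl produced a 5.0-fold higher number from compound 2 to compound 3 (0.70 log units; beyond the scatter), and the group that enters, like that piperidin-1-yl, carries a six-membered non-aromatic ring with one hetero atom. The most relevant measured guide is therefore that step taken in reverse, which points to a lower number for compound 4 of about the same size. Going by the values given here, no compound with an oxygen-linked group on this carbonyl carbon has been measured, so the range is kept wide. Compound 4 is estimated at 1500 nM, with a range from 500 nM to 4500 nM. The expected step is a 3.7-fold lower number from compound 3 to compound 4 (0.56 log units; beyond the scatter).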

Compound 4, half-maximal inhibitory concentration: 600 nM
Estimate against measurement, compound 4: 2.5-fold (0.40 log units) above; measured number inside the range.
By their numbers in this assay, from the lowest: compounds 4, 2 and 1 (each within the scatter of the next, the first and the last beyond it); then compound 3.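

On the carbonyl carbon attached to a saturated chain carbon, an oxygen-linked group is now measured, and the replacement of (2-((tert-butoxycarbonyl)amino)ethyl)amino by (2,2,6,6-tetramethylpiperidin-4-yl)oxy gives a 9.2-fold lower number from compound 3 to compound 4 (0.96 log units; beyond the scatter) even though both groups count the same number of heavy atoms, so heavy-atom count alone does not set the number at this position. Against the nitrogen-linked ring of the piperidin-1-yl group the change gives a 1.8-fold lower number from compound 2 to compound 4 (0.26 log units; within the scatter) and so stays within the scatter, which means that the oxygen link is tolerated here and that these two ring-bearing groups cannot be told apart. Against the shorter carbamate chain the change gives a 2.8-fold lower number from compound 1 to compound 4 (0.45 log units; beyond the scatter) and this step is beyond the scatter, although compound 1 does not separate from compound 2, so a simple division into ring-bearing groups and open chains does not hold for compound 1.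

Nothing at hand explains why the numbers move. Still open, as far as these compounds go, is whether the oxygen link, the four methyl groups or the ring nitrogen carries the result, which a plain piperidin-4-yloxy group or a 2,2,6,6-tetramethylpiperidin-4-ylamino group on the same carbonyl carbon would help to separate.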